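Replacing the urea tail of compound 1 with a plain benzamide

A few compounds are considered here, and "the series" means these few. Any claim that something is new, unique, unknown or untested is made for them only; others in the source may bear on it.

Compound 1 `COc1cc(-c2nn(-c3cccc(NC(=O)Nc4ccc(Cl)c(Cl)c4)c3)cc2-c2ccncc2)ccc1Cl` was examined in a functional assay on HCT-15 cells (Homo sapiens) for inhibition, read by sulforhodamine B assay, with a stated time of 48 h; a lower number here means that less compound is tolerated, a higher number that more compound is tolerated. In this assay compound 1 gives only a limit, > 50000 nM, so no number is known for it. Its closest relative, compound 2 `O=C(Nc1cccc(-n2cc(-c3ccncc3)c(-c3ccc(Cl)c(O)c3)n2)c1)Nc1ccc(Cl)c(Cl)c1`, also reaches only a limit of > 32500 nM in this assay. The step from compound 1 to compound 2, a step that the two limits leave unreadable from compound 1 to compound 2, therefore cannot be read, as the two limits the limit of > 50000 nM in this assay, at which 1 of the 3 values shown sits, and the limit of > 32500 nM in this assay, at which 1 of the 3 values shown sits, show. Going by the values given here, compound 3 `O=C(Nc1cccc(-n2cc(-c3ccncc3)c(-c3ccc(Cl)c(O)c3)n2)c1)Nc1cc(C(F)(F)F)cc(C(F)(F)F)c1` is the one relative with a number, giving 21200 nM in this assay.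

Compound 4 `COc1cc(-c2nn(-c3cccc(NC(=O)c4ccccc4)c3)cc2-c2ccncc2)ccc1Cl` differs from compound 1 by phenyl in place of (3,4-dichlorophenyl)amino on a carbonyl carbon, that is, a (3,4-dichlorophenyl)carbamoyl group becomes benzoyl and the urea becomes a benzamide. Among the compounds with values here, no measured step covers this change, and the position of compound 1 is known only as a limit. With compounds 1 and 2 both at limits and compound 3 weak, the expected step from compound 1 to compound 4 is a number no higher from compound 1 to compound 4 (the limit leaves the size open), with no change beyond the scatter foreseen. Compound 4 is therefore expected to give about 50000 nM in this assay, within 15000 nM to 160000 nM, most likely again reported only as a limit.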

Compound 4, concentration lethal to 50% of the cells: > 100000 nM
Compound 4 gave a limit, no number; the forecaster's own chance of this, stated with the estimate: 70%; middle value at least 2.0-fold (0.30 log units) away from the limit.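

Compound 1 and compound 4 both give only limits in this assay, so the step between them cannot be read. The compounds shown leave open whether phenyl in place of (3,4-dichlorophenyl)amino on a carbonyl carbon changes the result in this assay at all.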